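The source may hold more compounds than are shown below. What is called first, only, known or untested is meant among the compounds shown, and "the series" means these compounds.

Measured in a functional assay on SK-BR-3 cells (Homo sapiens) for antiproliferative activity; on this read-out lower numbers stand for stronger inhibition and higher numbers for weaker inhibition:
- compound 1 `C=CCc1cc(C(=O)Nc2cc3ccc(OC4CCN(C)CC4)c(C)c3oc2=O)ccc1O`: 2430 nM
- compound 2 `Cc1c(OC2CCN(C)CC2)ccc2cc(NC(=O)c3ccc(O)c(Cl)c3)c(=O)oc12`: 2300 nM

These two compounds share a core and differ in one group on the benzene-type ring that carries the hydroxy group. Within the data shown here, with only two numbers in hand, compound 2 at 2300 nM stands level with compound 1 within the usual scatter.

The next compound, compound 3 `COc1cccc(-c2cc(C(=O)Nc3cc4ccc(OC5CCN(C)CC5)c(C)c4oc3=O)ccc2O)c1`, changes that same place: 3-methoxyphenyl in place of chloro on an aromatic carbon. A 3-methoxyphenyl group replaces chloro, ortho to a hydroxy group.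

Among the measured compounds shown here, one measured step bears on this change: a 1.1-fold lower number from compound 1 to compound 2 (0.02 log units; within the scatter). That swap of allyl for chloro left the read-out within the scatter, so this place has tolerated a change of group so far. It is thin evidence, however. For the measured compounds named here, neither allyl nor chloro brings a ring, and no measured compound shows what an added aromatic ring does here.

No clear shift beyond the scatter is therefore predicted, although the uncertainty is wide. The step is expected to be small, and it is estimated as a 1.5-fold lower number from compound 2 to compound 3 (0.19 log units; within the scatter).

For compound 3 the estimated value is 1500 nM, with an expected range from 400 nM to 5000 nM.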

Compound 3, half-maximal inhibitory concentration: 860 nM
Compound 3: the middle estimate sits 1.7-fold (0.24 log units) above what was measured, within the range that was stated.
By their numbers in this assay, from the lowest: compound 3; then compounds 2 and 1 (each within the scatter of the next).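

In this assay, this position now shows a step beyond the scatter: 3-methoxyphenyl in place of chloro gives a 2.7-fold lower number from compound 2 to compound 3 (0.43 log units; beyond the scatter), and 3-methoxyphenyl in place of allyl gives a 2.8-fold lower number from compound 1 to compound 3 (0.45 log units; beyond the scatter). Compounds 1 and 2 could show only that swapping allyl and chloro left the number within the scatter, whereas compound 3 shows that a larger group, bringing a six-membered aromatic ring of carbon only and a hydrogen-bond acceptor, is tolerated ortho to a hydroxy group and goes with a modestly lower number. The data shown offer no explanation for this drop.

Going by these compounds, what remains open is whether the added ring alone accounts for the step or the methoxy group on it also contributes, a question that a plain phenyl group would address directly. On these data alone, it is also open how a ring containing nitrogen, such as pyridyl, or an added ring carrying an amine or a carboxylic acid would read out at this same place.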